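Methoxy in Place of Chloro: Expectation for Compound 3

This account rests on a few compounds, and the source may have more. Where it says the series, first, only, none or still open, it means among the compounds named here.

Compound 2 `O=C1/C(=C/c2cccc(Cl)c2)Cc2cc(O)ccc21` was tested in an assay on isolated protein for inhibition of Amine oxidase [flavin-containing] B (Homo sapiens), read by fluorescence and spectrophotometry, with a stated time of 20 min; a higher number here means a weaker inhibitor, a lower number a stronger inhibitor; in this assay compound 2 gives 30 nM. Compound 1 `O=C1/C(=C/c2ccccc2)Cc2ccc(O)cc21` was tested alongside it, and in this assay compound 1 gives 2420 nM, so compound 2 stands as the lower of the two values, a gap beyond the scatter. Compound 3 `COc1cccc(/C=C2\Cc3cc(O)ccc3C2=O)c1` differs from compound 2 by methoxy in place of chloro on an aromatic carbon. For the measured compounds named here, no measured pair shows this change, so its size must be judged from the change alone. A modest rise toward a weaker inhibitor is expected, a 3.3-fold higher number from compound 2 to compound 3 (0.52 log units; beyond the scatter). Compound 3 is therefore estimated at 100 nM, within a range from 30 nM to 400 nM.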

Compound 3, half-maximal inhibitory concentration: 471 nM
Compound 3: middle estimate off by 4.7-fold (0.67 log units), on the low side; the whole stated range lies below it.
By their numbers in this assay, from the lowest: compound 2; then compound 3; then compound 1.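

In this assay, methoxy in place of chloro on this aromatic carbon gives a large step: a 16-fold higher number from compound 2 to compound 3 (1.20 log units; beyond the scatter). For the compounds shown here, this is the first direct reading of what this position tolerates, which compound 1 and compound 2 could not give, as they differ in more than one place. Nothing measured here accounts for the size of this step. Going by these compounds, whether bromo, an amine or a longer ether chain at this carbon would behave like chloro or like methoxy stays open, as does the effect of methoxy elsewhere on the ring.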